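The compounds below may be only part of what the source reports. "The series", "measured", "known", "first", "only" and "open" are said of these compounds alone.

In a functional assay on HL-60 cells (Homo sapiens) for antiproliferative activity, read by MTT assay, with a stated time of 72 h (a higher number here means a weaker inhibitor, a lower number a stronger inhibitor), compound 1 (`COc1cc(C(=O)c2sc3ccccc3c2-c2ccc(SC)cc2)cc(OC)c1OC`) gives 1300 nM and compound 2 (`CCOc1ccc(-c2c(C(=O)c3cc(OC)c(OC)c(OC)c3)sc3ccccc23)cc1`) gives 3500 nM, the higher of the two numbers and so the weaker result. Compound 3 (`COc1cc(C(=O)c2sc3ccccc3c2Nc2ccccc2)cc(OC)c1OC`) has anilino in place of 4-ethoxyphenyl on an aromatic carbon. Within the data shown here, only one measured step offers guidance, a 2.7-fold higher number from compound 1 to compound 2 (0.43 log units; beyond the scatter), and it is modest. Among the measured compounds shown here, it swaps ethoxy for methylsulfanyl, and no measured compound carries anilino, so the guidance is weak. The expected change is similarly modest, towards a lower number: a 2.3-fold lower number from compound 2 to compound 3 (0.37 log units; beyond the scatter). Compound 3 is estimated at 1500 nM, with an expected range of 300 nM to 6000 nM.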

Compound 3, half-maximal inhibitory concentration: 5200 nM
Beside the measured number, compound 3's estimate is 3.5-fold (0.54 log units) below it, and the stated range covers the measured number.
By their numbers in this assay, from the lowest: compound 1; then compounds 2 and 3 (each within the scatter of the next).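

In this assay, the anilino group takes the place of 4-ethoxyphenyl with a 1.5-fold higher number from compound 2 to compound 3 (0.17 log units; within the scatter), so on this aromatic carbon these two groups cannot be told apart. Set against the 4-(methylsulfanyl)phenyl group, the same anilino group gives a 4.0-fold higher number from compound 1 to compound 3 (0.60 log units; beyond the scatter), which leaves compound 1 the stronger of that pair. No supporting data bear on why these numbers fall as they do.

Still open, as far as these compounds go, is whether a methylsulfanyl group on the anilino ring would bring compound 3 closer to compound 1. From the compounds shown here alone, how a non-aromatic amine such as morpholine would behave at this position also remains open.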